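Returning to a para-substituted aryl group on the shared core

The source may hold more compounds than are shown below. What is called first, only, known or untested is meant among the compounds shown, and "the series" means these compounds.

The shared core carries a trimethoxyphenyl group and a pendent aryl ring; compound 1 `COc1cc(-c2ccnc3cc(-c4ccc(C(F)(F)F)cc4)nn23)cc(OC)c1OC` bears the 4-(trifluoromethyl)phenyl variant and compound 2 `COc1cc(-c2ccnc3cc(-c4cccc(C)c4)nn23)cc(OC)c1OC` the 3-methylphenyl variant. In a functional assay on HeLa cells (Homo sapiens) for inhibition, read by CCK-8 assay, with a stated time of 48 h (a lower number here means a stronger inhibitor, a higher number a weaker inhibitor), compound 1 gives 1840 nM, and compound 2 gives 4230 nM. Compound 2 thus stands as the higher of the two numbers, the step of a 2.3-fold higher number from compound 1 to compound 2 (0.36 log units; beyond the scatter) being modest but beyond the scatter.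

Compound 3 `COc1cc(-c2ccnc3cc(-c4ccc(C(C)(C)C)cc4)nn23)cc(OC)c1OC` is the next step from compound 2: 4-(tert-butyl)phenyl in place of 3-methylphenyl on an aromatic carbon. The entering group is larger, with 10 heavy atoms against 7, and it sits on an aromatic carbon of the five-membered aromatic ring with 2 nitrogen, part of a fused system of two rings. Within the data shown here, the only step that bears on this is the one from compound 1 to compound 2, which shows that the 3-methylphenyl group gave the higher number. Among the measured compounds shown here, since compound 3 moves away from that group, a lower number is expected, on the order of the step of a 2.3-fold higher number from compound 1 to compound 2 (0.36 log units; beyond the scatter) reversed, though no tert-butyl analogue has been measured here. The expected step is a 2.1-fold lower number from compound 2 to compound 3 (0.33 log units; beyond the scatter), and compound 3 is estimated at 2000 nM in this assay, within 700 nM to 6000 nM.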

Compound 3, half-maximal inhibitory concentration: > 10000 nM
Compound 3: a limit, no number; the forecaster's own chance of this, stated with the estimate: 5%; middle value at least 5.0-fold (0.69 log units) from the limit.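

In this assay compound 3 is a limit of the assay and not a number: the limit of > 10000 nM in this assay, at which 1 of the 3 values shown sits. The earlier pair had shown only a modest spread at this aromatic carbon, whereas the change to 4-(tert-butyl)phenyl gives an at least 2.3-fold higher number from compound 2 to compound 3 (0.37 log units; beyond the scatter), and tert-butyl in place of trifluoromethyl on the same phenyl ring gives an at least 5.4-fold higher number from compound 1 to compound 3 (0.73 log units; beyond the scatter). The position therefore tolerates some aryl groups far better than others, and the numbered place of the substituent does not settle the outcome alone, since 4-(trifluoromethyl)phenyl gives the lowest number of the three compounds while 4-(tert-butyl)phenyl gives the limit.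

From the compounds shown here alone, compound 3 being a limit, how far it lies beyond the other two stays unknown, so both steps give only a minimum size. It also remains open whether a 4-methylphenyl, a 4-methoxyphenyl or a phenyl ring carrying an amine at the same place would fall nearer to compound 1 or to compound 3, and the compounds shown give no reason for the loss.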